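The compounds below may be only part of what the source reports. "The series", "measured", "known", "first", "only" and "open" are said of these compounds alone.

Compound 1 `COc1ccc(C(=O)/C=C/c2ccc(F)cc2)c2c1C=CC(C)(C)O2`, tested in a functional assay on SW-620 cells (Homo sapiens) for antiproliferative activity, read by MTT assay, with a stated time of 24 h (on this read-out lower numbers stand for stronger inhibition and higher numbers for weaker inhibition), sits at a limit of the assay rather than a number: > 10000 nM.
Compound 2 `COc1ccc(C(=O)/C=C/c2ccc(Br)cc2)c2c1C=CC(C)(C)O2` also sits at a limit of the assay in this assay: > 10000 nM.
Compound 3 `COc1ccc(C(=O)/C=C/c2ccc(N(C)C)cc2)c2c1C=CC(C)(C)O2` gives a number in this assay: 570 nM.

For the measured compounds named here, compound 3 stands alone with the only true number in this small set; the other two values are limits, as summarized by the limit of > 10000 nM in this assay, at which 2 of the 3 values shown sit. The steps leading to compound 3 are large: an at least 17-fold lower number from compound 1 to compound 3 (1.24 log units; beyond the scatter) and an at least 17-fold lower number from compound 2 to compound 3 (1.24 log units; beyond the scatter). The step between the two halogenated compounds cannot be read from the limits: a step that the two limits leave unreadable from compound 1 to compound 2.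

Compound 4 `COc1ccc(C(=O)/C=C/c2ccc(-c3ccccc3)cc2)c2c1C=CC(C)(C)O2` differs from compound 3 in one place: phenyl in place of dimethylamino on an aromatic carbon. Going by the values given here, no measured step exchanges dimethylamino for phenyl, so none bears directly on this change. The two measured steps do show, read in reverse, that removing dimethylamino from that position coincides with a number that rises beyond the assay's range, and phenyl, like the halogens, carries no hydrogen-bond acceptor. On that basis, compound 4 is expected to give a considerably higher number in this assay than compound 3, a step of about a 7.0-fold higher number from compound 3 to compound 4 (0.85 log units; beyond the scatter), with a real chance that only a limit is returned. The estimate for compound 4 in this assay is 4000 nM, within a range from 800 nM to 20000 nM.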

Compound 4, half-maximal inhibitory concentration: > 10000 nM
Compound 4 gave a limit, no number; the forecaster's own chance of this, stated with the estimate: 40%; middle value at least 2.5-fold (0.39 log units) from the limit.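

Until now dimethylamino had been compared only with the two halogens, so those steps could not show whether any larger, non-halogen group at this place would also give a measurable value. Phenyl now answers that for one such group: putting it in place of dimethylamino gives an at least 17-fold higher number from compound 3 to compound 4 (1.24 log units; beyond the scatter) in this assay, so neither leaving the halogens behind nor adding size is enough on its own here, and of the groups shown on this aromatic carbon, only dimethylamino gives a number. The steps from compound 1 and from compound 2 to compound 4 cannot be read, as all three compounds sit at one limit of the assay rather than at numbers: the limit of > 10000 nM in this assay, at which 3 of the 4 values shown sit.

The compounds shown leave open whether other amines at this place, such as a plain amino group, diethylamino or morpholine, would also give a number, and whether a methoxy group would do the same. They also leave open how far compound 1, compound 2 and compound 4 lie past their shared limit, and whether these three differ from one another at all.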